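The compounds below may be only part of what the source reports. "The series", "measured", "known", "first", "only" and "open" are said of these compounds alone.

Measured compounds:
compound 1 `CC1=C(/C=C/C(=O)/C=C/c2ccc(Br)cc2)C(C)(C)CCC1` — 88800 nM
compound 2 `COc1ccc(/C=C/C(=O)/C=C/C2=C(C)CCCC2(C)C)cc1` — 15700 nM

In a functional assay on HeLa cells (Homo sapiens) for cytotoxicity, read by sulforhodamine B assay, with a stated time of 48 h (on this read-out lower numbers stand for stronger inhibition and higher numbers for weaker inhibition), compound 1 gives 88800 nM, the highest of the two numbers; the nearest is compound 2, and the step of a 5.7-fold lower number from compound 1 to compound 2 (0.75 log units; beyond the scatter) is a modest one beyond the scatter, coming with a methoxy in place of bromo on an aromatic carbon.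

Compound 3 `CC1=C(/C=C/C(=O)/C=C/c2ccccc2F)C(C)(C)CCC1` is not yet measured. Against compound 1 the change is 2-fluorophenyl in place of 4-bromophenyl on a double-bonded chain carbon bound to a double-bonded chain carbon. For the measured compounds named here, no measured step covers this exchange: the only step in hand swaps the bromo for methoxy at the same aromatic carbon, whereas here the halogen changes and the ring is attached through a different carbon, so the step from compound 1 to compound 2 does not bear on it directly. It shows only that changing the substituent on this aryl ring can move the number beyond the scatter. With that, the expectation for compound 3 is a step of a 1.5-fold lower number from compound 1 to compound 3 (0.17 log units; within the scatter) in this assay, of modest size at most and in either direction, with a slight lean toward a lower number. The estimate for compound 3 in this assay is 60000 nM, with a range from 20000 nM to 160000 nM.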

Compound 3, half-maximal inhibitory concentration: 41900 nM
Estimate against measurement, compound 3: 1.4-fold (0.16 log units) above; the range from low to high includes it.
By their numbers in this assay, from the lowest: compound 2; then compound 3; then compound 1.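

In this assay the exchange of 4-bromophenyl for 2-fluorophenyl on a double-bonded chain carbon bound to a double-bonded chain carbon gives a 2.1-fold lower number from compound 1 to compound 3 (0.33 log units; beyond the scatter), so this position responds beyond the scatter to a second aryl group, here one that carries a halogen and has the same count of heavy atoms as the group it replaces. Until now the only replacement of 4-bromophenyl at this position was the methoxy-bearing aryl group of compound 2, and both replacements now give a lower number than compound 1, a pattern that rests on these two steps alone with neither compound going against it. Nothing measured on hand offers a reason for the step from 4-bromophenyl to 2-fluorophenyl.

This single exchange alters both the halogen and the way the ring is substituted, and the compounds shown cannot separate the share of each. They also leave open how a plain phenyl group, or an aryl group bearing an amine or a carboxylic acid, would read at this position on the core of compound 1.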